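The source may hold more compounds than are shown below. What is called first, only, known or untested is meant among the compounds shown, and "the series" means these compounds.

Measured compounds in a functional assay on MDA-MB-231 cells (Homo sapiens) for cytotoxicity, read by sulforhodamine B assay, with a stated time of 48 h; on this read-out higher numbers stand for weaker inhibition of growth and lower numbers for stronger inhibition of growth:
- compound 1, `Cc1ccc2nc(/N=C3\C(=O)N(CN4CCCCC4)c4cccc(Br)c43)sc2c1`, gives 38300 nM
- compound 2, `Cc1ccc2nc(/N=C3\C(=O)N(CN(C)C)c4cccc(Cl)c43)sc2c1`, gives 10900 nM
- compound 3, `Cc1ccc2nc(/N=C3\C(=O)N(CN(c4ccccc4)c4ccccc4)c4cccc(Cl)c43)sc2c1`, gives 54000 nM

Among these three, compound 2 has the lowest number in this assay, so it slows growth of the cells most strongly; its gaps to compound 1 and to compound 3 both lie beyond the usual scatter of repeated measurements.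

Compound 4, `Cc1ccc2nc(/N=C3\C(=O)N(CN4CCCCC4)c4cccc(Cl)c43)sc2c1`, has not yet been measured. It differs from compound 2 in one place: piperidin-1-yl in place of dimethylamino on a saturated chain carbon bound to an amide-type nitrogen in a ring. Compound 1 also carries piperidin-1-yl at that place, but it differs from compound 2 in a second place as well, so its value and that of compound 2 only show that the two differ; no single-point comparison exists here.

Given that the only other compound with piperidin-1-yl, compound 1, gives 38300 nM, a weakening step is expected from compound 2 to compound 4, a 2.2-fold higher number from compound 2 to compound 4 (0.34 log units; beyond the scatter), though a result within the scatter would not be surprising. For compound 4 the estimate in this assay is 24000 nM, with a likely range from 9000 nM to 65000 nM.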

Compound 4, concentration for 50% growth inhibition: 55800 nM
Beside the measured number, compound 4's estimate is 2.3-fold (0.37 log units) below it; measured number inside the range.
By their numbers in this assay, from the lowest: compound 2; then compounds 1, 3 and 4 (each within the scatter of the next).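

In this assay, among these compounds, this is the first comparison at this position that changes only the amine: piperidin-1-yl in place of dimethylamino on a saturated chain carbon bound to an amide-type nitrogen in a ring gives a 5.1-fold higher number from compound 2 to compound 4 (0.71 log units; beyond the scatter) with chloro kept on the core. Chloro in place of bromo on an aromatic carbon, with piperidin-1-yl kept, gives a 1.5-fold higher number from compound 1 to compound 4 (0.16 log units; within the scatter) and so cannot be told apart from no change. Among these two single changes, only the change of amine gives a readable difference.

On these data alone, whether pyrrolidin-1-yl, morpholin-4-yl or a longer chain before the amine would sit nearer compound 2 or compound 4 stays open, as does whether dimethylamino with bromo on the core would match compound 2. Nothing measured here explains the step from dimethylamino to piperidin-1-yl.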